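This account rests on a few compounds, and the source may have more. Where it says the series, first, only, none or still open, it means among the compounds named here.

Compound 1 `COc1ccc(/C=C/c2cc(OC)cc(OC)c2/C=C/C(=O)c2ccc(Cl)c(Cl)c2)cc1` gives 7.5 ug/mL in a functional assay on B16-F10 cells (Mus musculus) for antiproliferative activity, read by MTT assay, with a stated time of 48 h (on this read-out lower numbers stand for stronger inhibition and higher numbers for weaker inhibition), and stands with the highest number among the three measured compounds; its nearest neighbour is compound 3 `COc1ccc(/C=C/c2cc(OC)cc(OC)c2/C=C/C(=O)c2ccc(C)cc2)cc1` with 5.3 ug/mL, and its furthest is compound 2 `COc1ccc(/C=C/c2cc(OC)cc(OC)c2/C=C/C(=O)c2cccc(Cl)c2)cc1` with 3.3 ug/mL. Compound 4 `COc1ccc(/C=C/c2cc(OC)cc(OC)c2/C=C/C(=O)c2ccc(C)cc2C)cc1` differs from compound 1 by 2,4-dimethylphenyl in place of 3,4-dichlorophenyl on a carbonyl carbon. The step that bears most on this change is a 1.4-fold lower number from compound 1 to compound 3 (0.15 log units; within the scatter), where a methyl-bearing phenyl also replaced the 3,4-dichlorophenyl on the carbonyl carbon. The step of a 2.3-fold lower number from compound 1 to compound 2 (0.36 log units; beyond the scatter) is larger, but a 1.6-fold higher number from compound 2 to compound 3 (0.21 log units; within the scatter) offsets part of it. The expected step is therefore a 1.4-fold lower number from compound 1 to compound 4 (0.13 log units; within the scatter), a lowering that does not clearly pass beyond the scatter. Compound 4 is estimated at 5.5 ug/mL in this assay, with a range from 2.5 ug/mL to 12 ug/mL.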

Compound 4, half-maximal inhibitory concentration: 4 ug/mL
Compound 4: the middle estimate sits 1.4-fold (0.14 log units) above what was measured; measured number inside the range.
By their numbers in this assay, from the lowest: compounds 2, 4, 3 and 1 (each within the scatter of the next, the first and the last beyond it).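

In this assay, a ring with two methyl groups and no chlorine on the carbonyl carbon stays within the scatter of the 3,4-dichlorophenyl compound (a 1.9-fold lower number from compound 1 to compound 4 (0.27 log units; within the scatter)). Adding a second methyl to the ring also gives no readable change (a 1.3-fold lower number from compound 3 to compound 4 (0.12 log units; within the scatter)). The 3-chlorophenyl compound is likewise not separated from the dimethyl compound (a 1.2-fold higher number from compound 2 to compound 4 (0.08 log units; within the scatter)), so among these four, only compound 1 and compound 2 remain apart. As far as these compounds go, whether an amine or a carboxylic acid on this phenyl would move the number beyond the scatter stays open. Nothing available explains any of these steps.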